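The source may report more compounds than this note shows. Statements on the series, on what has been measured and on what is new or still open speak of the compounds shown alone.

In a functional assay on VCaP cells (Homo sapiens) for antiproliferative activity, read by CCK-8 assay, with a stated time of 6 days (a higher number here means a weaker inhibitor, a lower number a stronger inhibitor), compound 2 `C[C@@H](Cn1ccc(-c2ccc(C#N)c(Cl)c2)n1)NC(=O)c1ccccc1F` gives 2190 nM, the higher of the two actual numbers, and compound 1 `CC(O)c1ccc(C(=O)N[C@@H](C)Cn2ccc(-c3ccc(C#N)c(Cl)c3)n2)cc1` gives 910 nM. Compound 3 `CC(Cn1ccc(-c2ccc(C#N)c(Cl)c2)n1)C(=O)Nc1cccc(C(C)O)c1` gives > 30000 nM, which is a limit of the assay and not a number. Compound 4 `C[C@@H](Cn1ccc(-c2ccc(C#N)c(Cl)c2)n1)Nc1ccncc1` departs from compound 2 with pyridin-4-yl in place of (2-fluorophenyl)carbonyl on an amine nitrogen. Within the data shown here, only one measured step bears on this change, a 2.4-fold higher number from compound 1 to compound 2 (0.38 log units; beyond the scatter), a modest one that keeps the carbonyl compound 4 gives up, so it is a loose guide. A larger rise in the number, meaning weaker inhibition, is therefore expected. The expected step is a 2.7-fold higher number from compound 2 to compound 4 (0.44 log units; beyond the scatter). For compound 4 the estimated value is 6000 nM, with an expected range from 1500 nM to 25000 nM.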

Compound 4, half-maximal inhibitory concentration: 9900 nM
Estimate against measurement, compound 4: 1.7-fold (0.22 log units) below, and the stated range covers the measured number.
By their numbers in this assay, from the lowest: compound 1; then compound 2; then compound 4. At a limit, above all of these: compound 3.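

Setting pyridin-4-yl directly on the amine nitrogen in place of (2-fluorophenyl)carbonyl weakens inhibition in this assay, with a 4.5-fold higher number from compound 2 to compound 4 (0.66 log units; beyond the scatter). This nitrogen therefore still gives a measurable number without a carbonyl on it, although at a cost within this pair. Only compound 3 stands at a limit of the assay: the limit of > 30000 nM in this assay, at which 1 of the 4 values shown sits.

The step removes the carbonyl and exchanges the ring at once, so the compounds leave open which of the two accounts for the loss. A phenyl group or a pyridin-4-ylcarbonyl group on that nitrogen would separate them.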